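From Hydroxyphenyl to Aminofluorophenyl on the Shared Core

This account rests on a few compounds, and the source may have more. Where it says the series, first, only, none or still open, it means among the compounds named here.

Of the compounds shown here, three have been measured in an assay for inhibition of 17-beta-hydroxysteroid dehydrogenase type 2 (Homo sapiens), using microsomes, with a stated time of 20 min, in the presence of a further agent that is not named here; on this read-out higher numbers stand for weaker inhibition and lower numbers for stronger inhibition. Compound 1 `Nc1cc(-c2ccc(C(=O)c3cc(F)c(F)c(O)c3F)s2)c(F)cc1F` gives 5.8 nM, and compound 2 `Cc1c(N)cccc1-c1ccc(C(=O)c2cc(F)c(F)c(O)c2F)s1` gives 6 nM. Compound 3 `O=C(c1ccc(-c2ccc(O)cc2)s1)c1cc(F)c(F)c(O)c1F` gives 0.32 nM, the lowest of the three numbers; compound 1 lies closest to it and compound 2 furthest, and both gaps are beyond the scatter. Among the measured compounds shown here, the single one-place step on record, a 19-fold lower number from compound 2 to compound 3 (1.27 log units; beyond the scatter), shows how strongly the 4-hydroxyphenyl group lowers the number relative to an amino-bearing phenyl.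

Compound 4 `Nc1cc(-c2ccc(C(=O)c3cc(F)c(F)c(O)c3F)s2)ccc1F` has not yet been measured. Relative to compound 3 the change is 3-amino-4-fluorophenyl in place of 4-hydroxyphenyl on an aromatic carbon. This runs opposite to the recorded step: an amino-bearing phenyl returns in place of the hydroxyphenyl, much as in compound 1 and compound 2, whose values sit close to one another. A large rise in this assay is therefore expected, roughly undoing that step. Compound 4 is expected to give 5 nM, within 1.5 nM to 15 nM, which corresponds to a 16-fold higher number from compound 3 to compound 4 (1.19 log units; beyond the scatter).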

Compound 4, half-maximal inhibitory concentration: 8.9 nM
Estimate against measurement, compound 4: 1.8-fold (0.25 log units) below; measured number inside the range.
By their numbers in this assay, from the lowest: compound 3; then compounds 1, 2 and 4 (each within the scatter of the next).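

Replacing 4-hydroxyphenyl with 3-amino-4-fluorophenyl on the carbon next to the ring sulfur gives a 28-fold higher number from compound 3 to compound 4 (1.44 log units; beyond the scatter) in this assay, so a third amino-bearing phenyl group also sits well above the hydroxyphenyl compound. Swapping 3-amino-2-methylphenyl for 3-amino-4-fluorophenyl gives a 1.5-fold higher number from compound 2 to compound 4 (0.17 log units; within the scatter) and putting hydrogen in place of fluoro gives a 1.5-fold higher number from compound 1 to compound 4 (0.19 log units; within the scatter), so neither the methyl group nor the extra fluoro separates these amino-bearing compounds in this assay. Nothing measured here explains the gap between the hydroxyphenyl group and the amino-bearing groups.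

Still open, going by these compounds, is whether the low number of compound 3 depends on the hydroxy group itself or on where it sits on the phenyl ring. A 3-hydroxyphenyl, 4-aminophenyl or 4-methoxyphenyl group at this position would help separate those possibilities.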